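The source may hold more compounds than are shown below. What is called first, only, known or untested is meant among the compounds shown, and "the series" means these compounds.

Among the measured compounds shown here, compound 3 `c1ccc(-c2nc[nH]n2)c(NCC2=NCCN2)c1` stands highest among the three compounds measured so far: in a functional assay with Alpha-1D adrenergic receptor (Homo sapiens) as the target, read by calcium flux (a higher number here means a larger maximal response, a lower number a smaller maximal response), compound 3 gives 123%, while compound 1 `CCCn1ncnc1-c1ccccc1NCC1=NCCN1` gives 57% and compound 2 `CCn1ncnc1-c1ccccc1NCC1=NCCN1` gives 55%. Compound 4 `Cn1ncnc1-c1ccccc1NCC1=NCCN1` has not yet been measured. Relative to compound 3 it carries 1-methyl-1H-1,2,4-triazol-5-yl in place of 1H-1,2,4-triazol-3-yl on an aromatic carbon. For the measured compounds named here, no measured step repeats this exact change. Going by the values given here, the one step available, a number 2 percentage points lower from compound 1 to compound 2 (within the scatter), shows that shortening the saturated chain on the aromatic nitrogen hardly moves the response. Compound 4 shortens that chain by a further step of the same kind, so its response is expected to sit close to compound 2 and compound 1 rather than close to compound 3. The step of a number 67 percentage points lower from compound 3 to compound 4 (beyond the scatter) is therefore expected to be a large drop, well beyond the scatter, in this assay. For compound 4 the estimate in this assay is 56%, with a likely range from 40% to 75%.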

Compound 4, largest response reached (reported as maximal response), in percent of the reference or control that the assay uses: 116%
Beside the measured number, compound 4's estimate is 60 percentage points below it, and the stated range ends below it.
By their numbers in this assay, from the lowest: compounds 2 and 1 (each within the scatter of the next); then compounds 4 and 3 (each within the scatter of the next).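

In this assay, putting 1-methyl-1H-1,2,4-triazol-5-yl in place of 1H-1,2,4-triazol-3-yl on the aromatic carbon removes the hydrogen-bond donor, yet the two compounds cannot be told apart (a number 7 percentage points lower from compound 3 to compound 4 (within the scatter)). The chain on the aromatic nitrogen turns out to matter after all, which compounds 1 and 2 alone could not show: methyl gives a far larger response than ethyl (a number 61 percentage points higher from compound 2 to compound 4 (beyond the scatter)) or propyl (a number 59 percentage points higher from compound 1 to compound 4 (beyond the scatter)), although ethyl and propyl do not differ beyond the scatter. Nothing available explains this sharp break between methyl and the two longer chains.

From the compounds shown here alone, the swap of triazole groups changes the methyl and the point of attachment together, so their separate contributions stay unknown. Also open, going by these compounds, is how a cyclopropyl group or a hydroxyethyl chain on that nitrogen would respond.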